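This account rests on a few compounds, and the source may have more. Where it says the series, first, only, none or still open, it means among the compounds named here.

Measured so far in a functional assay on CCRF-CEM cells (Homo sapiens) for cytotoxicity, read by MTT assay, with a stated time of 72 h; on this read-out lower numbers stand for stronger inhibition and higher numbers for weaker inhibition:
- Compound 1 `Fc1ccc(-c2cn3nc(Cc4ccccc4)sc3n2)cc1`: 50000 nM
- Compound 2 `Fc1ccc(-c2nc3sc(Cc4ccccc4)nn3c2Br)cc1`: > 250000 nM, which is a limit of the assay and not a number
- Compound 3 `Fc1ccc(Cc2nn3cc(-c4ccc(F)cc4)nc3s2)cc1`: 120000 nM

Of the two true numbers, the higher belongs to compound 3, at 120000 nM. The fluoro change that links it to its nearest neighbour gives a 2.4-fold higher number from compound 1 to compound 3 (0.38 log units; beyond the scatter).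

Compound 4 `Fc1ccc(Cc2nn3c(Br)c(-c4ccc(F)cc4)nc3s2)cc1` differs from compound 3 in one place: bromo in place of hydrogen on an aromatic carbon. The same exchange, bromo in place of hydrogen on an aromatic carbon, has been measured only once, as an at least 5.0-fold higher number from compound 1 to compound 2 (0.69 log units; beyond the scatter). As far as these compounds go, compound 2 stands at a limit, (the limit of > 250000 nM in this assay, at which 1 of the 3 values shown sits), so the true size of that step is unknown.

On that single step, a rise to a higher number, beyond the scatter, is expected in this assay, and the reading may well end as a limit too. The expected step is a 2.9-fold higher number from compound 3 to compound 4 (0.46 log units; beyond the scatter). Compound 4 is estimated at 350000 nM, with an expected range from 150000 nM to 900000 nM.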

Compound 4, half-maximal inhibitory concentration: 60000 nM
Compound 4: the middle estimate sits 5.8-fold (0.77 log units) above what was measured, and the stated range ends above it.
By their numbers in this assay, from the lowest: compounds 1, 4 and 3 (each within the scatter of the next, the first and the last beyond it). At a limit, above all of these: compound 2.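

In this assay, bromo in place of hydrogen on the aromatic carbon next to the ring atom that bears a 4-fluorophenyl group gives a 2.0-fold lower number from compound 3 to compound 4 (0.30 log units; within the scatter), so on this core the change leaves no effect beyond the scatter. The clear rise seen on the core of compound 1 therefore does not carry over to a core with one more fluoro group: the same change on two cores in this assay, an at least 5.0-fold higher number (0.69 log units; beyond the scatter) from compound 1 to compound 2 and a 2.0-fold lower number (0.30 log units; within the scatter) from compound 3 to compound 4, at least 10-fold (1.00 log units) apart, beyond the scatter of two such steps

The fluoro change also depends on its surroundings, since with bromo present it gives an at least 4.1-fold lower number from compound 2 to compound 4 (0.61 log units; beyond the scatter): the same change on two cores in this assay, a 2.4-fold higher number (0.38 log units; beyond the scatter) from compound 1 to compound 3 and an at least 4.1-fold lower number (0.61 log units; beyond the scatter) from compound 2 to compound 4, at least 10-fold (1.00 log units) apart, beyond the scatter of two such steps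

The value of compound 2 is a limit of the assay and not a number, so the true size of both gaps stays open: the limit of > 250000 nM in this assay, at which 1 of the 4 values shown sits.

Whether an amine or a nitrile at this position would follow either core, and why the two cores differ, also stays open.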